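Adding a Hydroxy Group: Expected Effect on Cell Growth Inhibition

The compounds below may be only part of what the source reports. "The series", "measured", "known", "first", "only" and "open" are said of these compounds alone.

Compound 1 `CCCCCc1cccc(NC(=O)NCCCCl)c1` gives 24000 nM in a functional assay on M21 cells (Homo sapiens) for antiproliferative activity, with a stated time of 48 h; on this read-out lower numbers stand for stronger inhibition and higher numbers for weaker inhibition.
Compound 2 `CCCCC(O)c1cccc(NC(=O)NCCCCl)c1` gives 35000 nM in this assay.
Compound 3 `CCCCCc1cccc(NC(=O)NC(=O)CCl)c1` gives 3500 nM in this assay.

Among the three measured compounds, compound 3 shows the lowest number in this assay: its number is a 6.9-fold lower number from compound 1 to compound 3 (0.84 log units; beyond the scatter) compared with compound 1, and lower still compared with compound 2. Compound 4 `CCCCC(O)c1cccc(NC(=O)NC(=O)CCl)c1` has not yet been measured. It differs from compound 3 in one place: hydroxy in place of hydrogen on a saturated chain carbon bound to an aromatic carbon and a saturated chain carbon.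

For the measured compounds named here, one measured step bears directly on this change. Compound 1 and compound 2 differ in exactly the same way, and there the result was a 1.5-fold higher number from compound 1 to compound 2 (0.16 log units; within the scatter). That step did not move the number beyond the usual scatter of repeated measurements. Since the same change on the same part of the shared core is now applied to compound 3, the expectation is for a similar outcome: little or no shift beyond the scatter, with a slight lean toward a higher number.

Compound 4 is therefore estimated at 5000 nM in this assay, with a range of 2500 nM to 10000 nM, which corresponds to an expected step of a 1.4-fold higher number from compound 3 to compound 4 (0.15 log units; within the scatter).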

Compound 4, half-maximal inhibitory concentration: 4600 nM
Beside the measured number, compound 4's estimate is 1.1-fold (0.04 log units) above it, and the stated range covers the measured number.
By their numbers in this assay, from the lowest: compounds 3 and 4 (each within the scatter of the next); then compounds 1 and 2 (each within the scatter of the next).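

On a second core, pentyl to 1-hydroxypentyl again stays within the usual scatter: in this assay this change gives a 1.3-fold higher number from compound 3 to compound 4 (0.12 log units; within the scatter). The hydroxy change has now been read with two different groups on the amide-type nitrogen, 3-chloropropyl and (chloromethyl)carbonyl, and its size does not depend on which of the two is present: the same change on two cores in this assay, a 1.5-fold higher number (0.16 log units; within the scatter) from compound 1 to compound 2 and a 1.3-fold higher number (0.12 log units; within the scatter) from compound 3 to compound 4, 1.1-fold (0.05 log units) apart, within the scatter of two such steps The reverse check also holds, since (chloromethyl)carbonyl in place of 3-chloropropyl still gives a 7.6-fold lower number from compound 2 to compound 4 (0.88 log units; beyond the scatter) with the hydroxy in place, much like the same change without it: the same change on two cores in this assay, a 6.9-fold lower number (0.84 log units; beyond the scatter) from compound 1 to compound 3 and a 7.6-fold lower number (0.88 log units; beyond the scatter) from compound 2 to compound 4, 1.1-fold (0.05 log units) apart, within the scatter of two such steps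

The compounds shown carry only hydrogen or hydroxy on this chain carbon, so it remains open whether a methoxy group, an amine or a ketone carbonyl there would also leave the number within the scatter. Going by these compounds, it also remains open whether the same holds on a shorter or longer chain than pentyl, or whether the (chloromethyl)carbonyl change keeps its size with one of those other groups in place.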